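A few compounds are considered here, and "the series" means these few. Any claim that something is new, unique, unknown or untested is made for them only; others in the source may bear on it.

Measured in a functional assay on RKO cells (Homo sapiens) for inhibition, read by MTT assay, with a stated time of 48 h; a lower number here means a stronger inhibitor, a higher number a weaker inhibitor:
compound 1 `COc1ccc(N(C)c2nc(C)nc3ccccc23)cc1C(=O)OCC[Se]C#N` gives 2390 nM;
compound 2 `COc1ccc(N(C)c2nc(C)nc3ccccc23)cc1OCCCCCC[Se]C#N` gives 1540 nM;
compound 3 `Cc1nc(N(C)c2ccc([Se]C#N)c(C)c2)c2ccccc2n1` gives 17 nM.

Compound 1 gives the highest number of the three in this assay; compound 2 sits within the scatter of it, while compound 3 lies far lower. Among the measured compounds shown here, compound 4 `COc1ccc(N(C)c2nc(C)nc3ccccc23)cc1OCCCC[Se]C#N` differs from compound 1 as follows: a group of 8 heavy atoms (5 carbon, 1 nitrogen, 1 oxygen, 1 selenium; no ring) in place of a group of 8 heavy atoms (4 carbon, 1 nitrogen, 2 oxygen, 1 selenium; no ring), on an aromatic carbon The one measured step that bears on this is a 1.6-fold lower number from compound 1 to compound 2 (0.19 log units; within the scatter), where a group on the same aromatic carbon was exchanged for a longer chain of similar make-up. Compound 4 carries a chain of a length between those of compound 1 and compound 2, so no step beyond the scatter is expected. The estimate for compound 4 in this assay is 1800 nM, range 900 nM to 3600 nM. This amounts to an expected 1.3-fold lower number from compound 1 to compound 4 (0.12 log units; within the scatter).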

Compound 4, half-maximal inhibitory concentration: 1360 nM
Compound 4: the middle estimate sits 1.3-fold (0.12 log units) above what was measured; the range from low to high includes it.
By their numbers in this assay, from the lowest: compound 3; then compounds 4, 2 and 1 (each within the scatter of the next).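

In this assay, the exchange on this aromatic carbon removes the double bond and one hydrogen-bond acceptor and gives a 1.8-fold lower number from compound 1 to compound 4 (0.24 log units; within the scatter), so the carbonyl-containing group and its replacement cannot be told apart here. Changing the group on the saturated chain carbon gives a 1.1-fold lower number from compound 2 to compound 4 (0.05 log units; within the scatter), so no dependence on chain length can be read across these two chains. No available data explain either result.

Still open, going by these compounds, is whether a shorter chain or a much longer chain would stay at this level. Also open, on these data alone, is whether an amine or a carboxylic acid in place of the selenocyanate end would do so.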